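Changing the group on the carbonyl: working notes

This account rests on a few compounds, and the source may have more. Where it says the series, first, only, none or still open, it means among the compounds named here.

Measured so far in a functional assay on PC-3 cells (Homo sapiens), read by MTT assay, with a stated time of 48 h; a higher number here means a weaker inhibitor, a lower number a stronger inhibitor
- compound 1 `CCn1c(C(=O)N(CCC#N)CCC#N)ccc1C(CC)(CC)c1ccc(OCC(O)C(C)(C)C)c(C)c1` gives 7800 nM
- compound 2 `CCn1c(C(=O)Oc2ccc(CCO)cc2)ccc1C(CC)(CC)c1ccc(OCC(O)C(C)(C)C)c(C)c1` gives 6300 nM

Within the data shown here, compound 2 stands within the scatter of compound 1, the only other number so far, so no order can be drawn between them. Among the measured compounds shown here, compound 3 `CCn1c(C(=O)OCc2ccc(F)cc2)ccc1C(CC)(CC)c1ccc(OCC(O)C(C)(C)C)c(C)c1` keeps the shared core and differs from compound 2 by 4-fluorobenzyl in place of 4-(2-hydroxyethyl)phenyl on an oxygen next to a carbonyl group as its one change. For the measured compounds named here, the only measured step that bears on this is a 1.2-fold lower number from compound 1 to compound 2 (0.09 log units; within the scatter) and it is a different exchange, of a whole group on the carbonyl carbon. No measurement here tests 4-fluorobenzyl itself. In this assay no step beyond the scatter is therefore expected. The estimated step is a 1.1-fold lower number from compound 2 to compound 3 (0.02 log units; within the scatter) and it carries wide margins. Compound 3 is expected at 6000 nM with an estimated range from 2500 nM to 14000 nM in this read-out.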

Compound 3, half-maximal inhibitory concentration: > 50000 nM
Compound 3: no number, only a limit; the forecaster's own chance of this, stated with the estimate: 8%; middle value at least 8.3-fold (0.92 log units) away from the limit.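

In this assay, among these compounds, the group on the oxygen next to a carbonyl group proves able to shift the read-out: 4-fluorobenzyl in place of 4-(2-hydroxyethyl)phenyl gives an at least 7.9-fold higher number from compound 2 to compound 3 (0.89 log units; beyond the scatter), whereas the only earlier step lay within the scatter. Exchange of the whole group on the carbonyl carbon gives an at least 6.4-fold higher number from compound 1 to compound 3 (0.80 log units; beyond the scatter), so the two earlier groups on that carbon are not interchangeable with every other group there. Compound 3 gives a limit and not a number, so both steps have a lower bound only: the limit of > 50000 nM in this assay, at which 1 of the 3 values shown sits.

The compounds shown do not tell whether the fluorine, the benzyl group or the loss of the hydroxyl carries this step. Also open, from the compounds shown here alone, is how an unsubstituted benzyl, a 4-(2-aminoethyl)phenyl or a carboxylic acid on that ring would read in this assay.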